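The compounds below may be only part of what the source reports. "The series", "measured", "known", "first", "only" and "open" are said of these compounds alone.

Among the measured compounds shown here, in a functional assay on the whole organism (Hindlimb, strain albino) with Mus musculus as the target, in the maximal electroshock model, with a stated time of 0.5 h (on this read-out higher numbers stand for an effect only at larger amounts of compound and lower numbers for an effect already at smaller amounts), compound 1 (`CC(=O)N1N=C(Nc2nc3ccc(Cl)cc3s2)CC1c1ccccc1`) gives 161 umol/kg and compound 2 (`CC(=O)N1N=C(Nc2nc3ccc([N+](=O)[O-])cc3s2)CC1c1ccc(Cl)cc1`) gives 132 umol/kg so that the only two numbers lie within the scatter of each other. Compound 3 (`CC(=O)N1N=C(Nc2nc3ccc([N+](=O)[O-])cc3s2)CC1c1ccccc1`) has no number yet. It differs from compound 2 by hydrogen in place of chloro on an aromatic carbon in a single place: hydrogen in place of chloro on an aromatic carbon, or 4-chlorophenyl to phenyl. For the measured compounds named here, no measured pair shows this change alone, so the size of the step cannot be read from the data. With compound 2 at 132 umol/kg as the starting point, no step beyond the scatter is expected in this assay for this change. The estimated change is a 1.1-fold higher number from compound 2 to compound 3 (0.06 log units; within the scatter) and it is expected to stay within the scatter. Compound 3 is expected at 150 umol/kg with an estimated range from 70 umol/kg to 320 umol/kg on this read-out.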

Compound 3, dose for half-maximal effect: 216 umol/kg
Compound 3: middle estimate off by 1.4-fold (0.16 log units), on the low side; the measured number falls inside the stated range.
By their numbers in this assay, from the lowest: compounds 2, 1 and 3 (each within the scatter of the next).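

In this assay, among the compounds shown here, the change from 4-chlorophenyl to phenyl now has a measured size (a 1.6-fold higher number from compound 2 to compound 3 (0.21 log units; within the scatter)), so removing this chloro gives no step beyond the scatter in the one pair available. The series also gains a pair for the other varied position, with nitro in place of chloro on an aromatic carbon (a 1.3-fold higher number from compound 1 to compound 3 (0.13 log units; within the scatter)), and this step too stays within the scatter. Neither change therefore separates its two compounds on this read-out, and no measurement bears on the reason for this.

Going by these compounds, each change rests on a single pair, so it remains open whether either step would hold on a different background. Also open, on these data alone, is whether an amine, a methoxy group or a carboxylic acid at either position would give a step beyond the scatter.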